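This account rests on a few compounds, and the source may have more. Where it says the series, first, only, none or still open, it means among the compounds named here.

Compound 1 `CC(C)Oc1cc(C(=O)N(C)C)nn1-c1ccccc1` gives 43.9% in a functional assay on the whole organism (strain Wistar) for inhibition, with Rattus norvegicus as the target, read by paw edema, with stated times of 30 min and 3 h, at a dose of 100 mg/kg by the oral route; on this read-out higher numbers stand for more inhibition at the one dose given (going by the name of the read-out) and lower numbers for less inhibition.
Compound 2 `CCCCOc1cc(C(=O)NC)nn1-c1ccccc1` gives 65% in this assay.
Compound 3 `CCCCOc1cc(C(=O)NCC)nn1-c1ccccc1` gives 0% in this assay.

Compound 3 stands lowest of these three numbers: compound 1 lies well above it and compound 2 higher still, both gaps beyond the scatter. Compound 4 `CCCCOc1cc(C(=O)N(C)C)nn1-c1ccccc1` shares the core of compound 3 and differs from it only at the amide: dimethylamino in place of ethylamino on a carbonyl carbon. Cut one bond further out, the same difference reads ethylcarbamoyl to dimethylcarbamoyl. Among the compounds with values here, the one measured step touching this amide-type nitrogen is a number 65 percentage points lower from compound 2 to compound 3 (beyond the scatter), where methyl in place of hydrogen on the saturated chain carbon bound to that nitrogen produced a large drop. Compound 4 keeps the same atoms as compound 3 but joins them differently. Compound 1 also carries dimethylamino, though it differs from compound 4 elsewhere too; in this assay compound 1 gives 43.9%, a number lying between compound 3 and compound 2. Because compound 1 gives 43.9%, compound 4 is expected to lie well above compound 3. The expected step is a number 40 percentage points higher from compound 3 to compound 4 (beyond the scatter). The estimate for compound 4 is 40%, with a range from 10% to 65%.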

Compound 4, a percentage reported as inhibition, in the whole organism at one dose (the size of the read-out at that dose, not a potency): 18.7%
The estimate for compound 4 lay 21.3 percentage points above the measured number, within the range that was stated.
By their numbers in this assay, from the lowest: compound 3; then compound 4; then compound 1; then compound 2.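

In this assay the arrangement of the same atoms at this amide matters: dimethylamino in place of ethylamino on a carbonyl carbon gives a number 18.7 percentage points higher from compound 3 to compound 4 (beyond the scatter) and restores only part of the read-out. Methyl in place of hydrogen on the amide-type nitrogen gives a number 46.3 percentage points lower from compound 2 to compound 4 (beyond the scatter), a smaller loss than methyl added on the chain carbon, which gives a number 65 percentage points lower from compound 2 to compound 3 (beyond the scatter). With dimethylamino held fixed, butyl in place of isopropyl on an oxygen on an aromatic ring gives a number 25.2 percentage points lower from compound 1 to compound 4 (beyond the scatter), so the ether group also moves this read-out.

No measurement shown here explains any of these steps. Still open, going by these compounds, is how a propyl chain on the amide nitrogen, or a morpholine amide in place of dimethylamino, would read.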